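The source may report more compounds than this note shows. Statements on the series, on what has been measured and on what is new or still open speak of the compounds shown alone.

In a functional assay on B16-F10 cells (Mus musculus) for antiproliferative activity, read by ELISA and MTT assay, with a stated time of 48 h (a lower number here means a stronger inhibitor, a higher number a weaker inhibitor), compound 1 `O=C(/C=C/c1ccc(F)cc1)NS(=O)(=O)c1ccc(Br)cc1` gives 2.8 ug/mL, and compound 2 `O=C(/C=C/c1ccc(Cl)cc1)NS(=O)(=O)c1ccc(Br)cc1` gives 2.8 ug/mL. The two differ by chloro in place of fluoro on an aromatic carbon, and the step from compound 1 to compound 2 is no change at the digits printed from compound 1 to compound 2 (within the scatter). Compound 3 `CN(C)c1ccc(/C=C/C(=O)NS(=O)(=O)c2ccc(F)cc2)cc1` shares only part of its structure with them; how its core differs from the core of compound 1 is not broken down here. In this assay compound 3 gives 2.3 ug/mL, a number within the scatter of those of compound 1 and compound 2. Compound 4 `CN(C)c1ccc(/C=C/C(=O)NS(=O)(=O)c2ccc(Cl)cc2)cc1` is not yet measured; it differs from compound 3 by chloro in place of fluoro on an aromatic carbon, the same change that turns compound 1 into compound 2. Because that earlier step gave no change at the digits printed from compound 1 to compound 2 (within the scatter), compound 4 is expected to show a step of no change at the digits printed from compound 3 to compound 4 (within the scatter). Resting on compound 3 at 2.3 ug/mL, compound 4 is estimated at 2.3 ug/mL, most likely between 1.2 ug/mL and 4.5 ug/mL.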

Compound 4, half-maximal inhibitory concentration: 2.8 ug/mL
Compound 4: the middle estimate sits 1.2-fold (0.09 log units) below what was measured; low and high end bracket the measured number.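

In this assay, chloro in place of fluoro on an aromatic carbon gives a 1.2-fold higher number from compound 3 to compound 4 (0.09 log units; within the scatter). Set beside the earlier step, the change carries over to the second core with no difference that can be told apart: the same change on two cores in this assay, no change at the digits printed (within the scatter) from compound 1 to compound 2 and a 1.2-fold higher number (0.09 log units; within the scatter) from compound 3 to compound 4, 1.2-fold (0.09 log units) apart, within the scatter of two such steps. This shows that, in these two pairs, the exchange of fluoro for chloro leaves the number within the scatter on both cores, but it does not show that the same would hold on any further core, and it gives no reason for the result.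

The compounds shown leave open whether a methoxy group, a nitro group or a carboxylic acid in place of the halogen would give a step beyond the scatter. They also leave open what a primary amine in place of the dimethylamino group would do.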